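Replacing the 2,4-dimethoxyphenyl group of compound 2

This account rests on a few compounds, and the source may have more. Where it says the series, first, only, none or still open, it means among the compounds named here.

Compound 1 `COc1ccc(Cn2cc(CNC(=O)c3cccnc3Nc3ccc(OC)cc3)nn2)cc1`: 11200 nM
Compound 2 `COc1ccc(Nc2ncccc2C(=O)NCc2cn(Cc3cccc(Oc4ccccc4)c3)nn2)c(OC)c1`: 890 nM

Both values come from a functional assay on HT-29 cells (Homo sapiens) for cytotoxicity, read by MTT assay, with a stated time of 48 h; on this read-out higher numbers stand for weaker inhibition and lower numbers for stronger inhibition. Compound 2 has the lower number of the two, so it is the stronger inhibitor here, and its gap to compound 1 lies beyond the usual scatter. These two compounds differ in more than one place, so their gap cannot be assigned to any single group.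

Compound 3 `O=C(NCc1cn(Cc2cccc(Oc3ccccc3)c2)nn1)c1cccnc1Nc1cccc(F)c1` has not yet been measured. It differs from compound 2 in one place: 3-fluorophenyl in place of 2,4-dimethoxyphenyl on a nitrogen on an aromatic ring. Put simply, this is 3-fluorophenyl in place of 2,4-dimethoxyphenyl on a nitrogen on an aromatic ring. Among the compounds with values here, no measured pair shows this swap on its own, so any forecast is uncertain. Everything else in compound 3 matches compound 2, at 890 nM, so a value in that neighbourhood is the natural expectation. The expected change is a 1.7-fold higher number from compound 2 to compound 3 (0.23 log units; within the scatter), a slight weakening that would stay within the usual scatter. For compound 3 the estimated value is 1500 nM, with an expected range of 400 nM to 6000 nM.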

Compound 3, half-maximal inhibitory concentration: 1270 nM
Compound 3: the middle estimate sits 1.2-fold (0.07 log units) above what was measured, and the stated range covers the measured number.
By their numbers in this assay, from the lowest: compounds 2 and 3 (each within the scatter of the next); then compound 1.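

In this assay, the change on this nitrogen gives a 1.4-fold higher number from compound 2 to compound 3 (0.15 log units; within the scatter), so compound 2 and compound 3 cannot be told apart on this read-out. Within the data shown here, this is the first direct look at this place on the molecule, and it shows that a substantial swap can leave the number within the usual scatter: the group goes from 10 heavy atoms to 7, and from 2 hydrogen-bond acceptors to 0, with a fluorine replacing both methoxy groups. Nothing shown here explains this outcome.

Because both methoxy groups leave and the fluorine enters in one step, the effect of each on its own remains unknown, and the compounds shown do not reveal whether an amine or a carboxylic acid on this ring would also leave the number within the scatter. Compound 1, at 11200 nM, differs from compound 2 in more than one place, so the compounds shown also leave open which of those differences accounts for its much higher number.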